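Cyano in place of methoxy: working notes on clearance

The compounds below may be only part of what the source reports. "The series", "measured", "known", "first", "only" and "open" are said of these compounds alone.

Measured in an in vitro ADME assay on microsomes from liver (Mus musculus) for pharmacokinetics, read by LC-MS; a higher number here means faster removal of the compound, a lower number slower removal:
- compound 1 `Cc1nc2cc(OC(F)(F)F)ccc2n1-c1ccc(C(=O)NC2CC2)s1`: 43 mL/min/kg
- compound 2 `COc1cccc2c1nc(C)n2-c1ccc(C(=O)NC2CC2)s1`: > 72 mL/min/kg (a limit)

For compound 2 the reading of > 72 mL/min/kg is a limit of this assay and not a number. Compound 2 sits at the limit of > 72 mL/min/kg in this assay, at which 1 of the 2 values shown sits. Among the measured compounds shown here, no step between measured compounds is available, so the series offers one numeric reading only, compound 1 at 43 mL/min/kg.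

Compound 3 `Cc1nc2c(C#N)cccc2n1-c1ccc(C(=O)NC2CC2)s1` carries cyano in place of methoxy on an aromatic carbon of compound 2 (cyano in place of methoxy on an aromatic carbon). The position is on the six-membered aromatic ring of carbon only, ortho to a fused ring and meta to a fused ring. For the measured compounds named here, a fall in clearance is expected, with compound 1 at 43 mL/min/kg as the only guide to its size. The expected change is an at least 1.6-fold lower number from compound 2 to compound 3 (0.20 log units; that floor lies within the scatter), and this estimate is loose. For compound 3 the estimated clearance is 45 mL/min/kg, with an expected range of 25 mL/min/kg to 72 mL/min/kg.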

Compound 3, clearance: 26 mL/min/kg
Compound 3: middle estimate off by 1.7-fold (0.24 log units), on the high side, within the range that was stated.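

In this assay, among the compounds shown here, cyano in place of methoxy on an aromatic carbon gives an at least 2.7-fold lower number from compound 2 to compound 3 (0.44 log units; beyond the scatter), the first step that can be read, and it lies beyond the scatter. The reading for compound 2 is a limit of the assay and not a number, so the step is a floor and its full size remains unknown: the limit of > 72 mL/min/kg in this assay, at which 1 of the 3 values shown sits.

The groups that leave and enter match in heavy atoms and hydrogen-bond acceptors, so these counts do not separate compound 2 from compound 3.

As far as these compounds go, it remains open whether another group on this aromatic carbon, such as an amine or a carboxylic acid, would give a similar step. The compounds shown also do not tell whether cyano would give the same step on another carbon of this ring.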